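This account rests on a few compounds, and the source may have more. Where it says the series, first, only, none or still open, it means among the compounds named here.

Measured so far in a functional assay on B16-F10 cells (Homo sapiens) for cytotoxicity against B16-F10 (Mus musculus), read by MTT assay, with a stated time of 72 h; on this read-out lower numbers stand for an effect already at smaller amounts and higher numbers for an effect only at larger amounts of compound:
Compound 1, `O=C1/C(=C\c2ccccc2Cl)c2ccccc2N1c1c(Cl)cccc1Cl`: compound 1 gives 39 ug/mL.
Compound 2, `CN(C)c1ccc(/C=C2\C(=O)N(c3c(Cl)cccc3Cl)c3ccccc32)cc1`: compound 2 gives > 100 ug/mL, a limit of the assay.
Compound 3, `O=C1/C(=C\c2ccccc2[N+](=O)[O-])c2ccccc2N1c1c(Cl)cccc1Cl`: compound 3 gives > 100 ug/mL, a limit of the assay.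

Compound 3 thus stands at the limit of this assay, where no number was read; this is the limit of > 100 ug/mL in this assay, at which 2 of the 3 values shown sit. Compound 4, `O=C1/C(=C\c2cccc(Cl)c2)c2ccccc2N1c1c(Cl)cccc1Cl`, is not yet measured. It differs from compound 3 in one place: 3-chlorophenyl in place of 2-nitrophenyl on a double-bonded chain carbon bound to a double-bonded ring carbon. For the measured compounds named here, the chlorine enters as 3-chlorophenyl rather than the 2-chlorophenyl of compound 1, so no measured step matches exactly. The nearest is an at least 2.5-fold higher number from compound 1 to compound 3 (0.40 log units; beyond the scatter), which shows that nitro in place of chloro moved the number up to the limit. Going back from nitro to a chloro-bearing ring is therefore expected to bring the number down again, a step estimated at an at least 2.0-fold lower number from compound 3 to compound 4 (0.30 log units; that floor lies within the scatter). The step that the two limits leave unreadable from compound 2 to compound 3 gives no size to lean on. Compound 4 is expected to give about 50 ug/mL, with a range from 20 ug/mL to 120 ug/mL.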

Compound 4, concentration for half-maximal effect: 8 ug/mL
Estimate against measurement, compound 4: 6.3-fold (0.80 log units) above; the whole stated range lies above it.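

In this assay, the place of the chlorine on the ring matters, not only its presence: 3-chlorophenyl in place of 2-chlorophenyl gives a 4.9-fold lower number from compound 1 to compound 4 (0.69 log units; beyond the scatter). The 3-chlorophenyl ring also stands apart from the other two rings, with 3-chlorophenyl in place of 2-nitrophenyl giving an at least 12-fold lower number from compound 3 to compound 4 (1.09 log units; beyond the scatter) and 3-chlorophenyl in place of 4-(dimethylamino)phenyl giving an at least 12-fold lower number from compound 2 to compound 4 (1.09 log units; beyond the scatter). Both of these steps start from a limit rather than a number, so their sizes are only floors: the limit of > 100 ug/mL in this assay, at which 2 of the 4 values shown sit.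

As far as these compounds go, whether a fluorine, a methoxy group or an amine in the place of this chlorine would also keep the number low remains open. From the compounds shown here alone, it is equally open whether the gain from 3-chlorophenyl would hold with the rest of the shared core changed.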